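Removing the benzyl group from a piperazine-bearing thiazolidinone

A few compounds are considered here, and "the series" means these few. Any claim that something is new, unique, unknown or untested is made for them only; others in the source may bear on it.

Two members of this series share a common core, differing only in the substituent on the piperazine nitrogen. Compound 1 `COC(=O)c1ccc(C2SCC(=O)N2c2ccc(N3CCN(Cc4cccc(C)c4)CC3)cn2)c(OC)c1` carries a 3-methylbenzyl group, and in a functional assay on K562 cells (Homo sapiens) for antiproliferative activity, read by MTT assay and trypan blue exclusion, with a stated time of 72 h (on this read-out higher numbers stand for weaker inhibition and lower numbers for stronger inhibition), compound 1 reaches only the limit of > 100000 nM. Compound 2 `COC(=O)c1ccc(C2SCC(=O)N2c2ccc(N3CCN(Cc4ccc(Cl)c(Cl)c4)CC3)cn2)c(OC)c1` carries a 3,4-dichlorobenzyl group instead, and in this assay compound 2 likewise gives only the limit of > 100000 nM. The step that the two limits leave unreadable from compound 1 to compound 2 therefore cannot be read, since both values sit at the limit of > 100000 nM in this assay, at which 2 of the 2 values shown sit, and no number separates them.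

Compound 3 `COC(=O)c1ccc(C2SCC(=O)N2c2ccc(N3CCNCC3)cn2)c(OC)c1` differs from compound 2 by the change (hydrogen in place of 3,4-dichlorobenzyl on an amine nitrogen in a ring), leaving the ring nitrogen bare. Going by the values given here, no measured step bears directly on this removal. With both known compounds at the limit, compound 3 is expected to remain at or near that limit, an estimated 150000 nM with a range from 30000 nM to 1000000 nM. The step that the limit leaves unreadable from compound 2 to compound 3 expected from this estimate is thus essentially none beyond the scatter.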

Compound 3, half-maximal inhibitory concentration: 15200 nM
Estimate against measurement, compound 3: 9.9-fold (0.99 log units) above; the whole stated range lies above it.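

In this assay, hydrogen in place of 3,4-dichlorobenzyl on the amine nitrogen in the ring gives an at least 6.5-fold lower number from compound 2 to compound 3 (0.81 log units; beyond the scatter), and hydrogen in place of 3-methylbenzyl gives an at least 6.5-fold lower number from compound 1 to compound 3 (0.81 log units; beyond the scatter). This position therefore does affect the read-out: taking away the whole benzyl group yields a measurable number, which exchanging one of the two substituted benzyl groups for the other could not show. The values of compound 1 and compound 2 are limits and not numbers, so the true size of both steps and the step between those two compounds cannot be read: the limit of > 100000 nM in this assay, at which 2 of the 3 values shown sit.

From the compounds shown here alone, whether a small group such as methyl or acetyl on this nitrogen would keep the number of compound 3 remains open. So does whether an unsubstituted benzyl group or a longer chain carrying the phenyl ring would return to the limit.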